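Removing a Methyl from the Core of Compound 2

A few compounds are considered here, and "the series" means these few. Any claim that something is new, unique, unknown or untested is made for them only; others in the source may bear on it.

Measured compounds:
compound 1, `Cc1ccc2c(O)cc(-c3cccc(Cl)c3)nc2n1`, 31.6 nM;
compound 2, `Cc1cc(C)c2c(O)cc(-c3cccc4ccccc34)nc2n1`, 468 nM;
compound 3, `Cc1cc(C)c2c(O)cc(-c3cccc(Cl)c3)nc2n1`, 117 nM.

In a functional assay on SK-MEL-5 cells (Homo sapiens) for antiproliferative activity (a higher number here means a weaker inhibitor of growth, a lower number a stronger inhibitor of growth), compound 1 gives 31.6 nM, compound 3 gives 117 nM and compound 2 gives 468 nM, the highest of the three. Compound 2 and compound 3 differ in their cores, and that difference is not broken down here. Between compound 3 and compound 1 the change is hydrogen in place of methyl on an aromatic carbon, and it gave a 3.7-fold lower number from compound 3 to compound 1 (0.57 log units; beyond the scatter) in this assay.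

The unmeasured compound 4, `Cc1ccc2c(O)cc(-c3cccc4ccccc34)nc2n1`, differs from compound 2 by hydrogen in place of methyl on an aromatic carbon, the same change made at the same kind of place. Because the step of a 3.7-fold lower number from compound 3 to compound 1 (0.57 log units; beyond the scatter) was modest but beyond the scatter, compound 4 is expected to give a 3.6-fold lower number from compound 2 to compound 4 (0.56 log units; beyond the scatter) in this assay. This rests on one example alone. Compound 4 is therefore estimated at 130 nM, plausibly between 50 nM and 330 nM.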

Compound 4, concentration for 50% growth inhibition: 13.8 nM
The estimate for compound 4 lay 9.4-fold (0.97 log units) above the measured number, outside the stated range (below it).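

In this assay the loss of the methyl gave a 34-fold lower number from compound 2 to compound 4 (1.53 log units; beyond the scatter) and so lowered the number on this core too. The direction of the step therefore carried from one core to the other, but its size did not: the same change on two cores in this assay, a 3.7-fold lower number (0.57 log units; beyond the scatter) from compound 3 to compound 1 and a 34-fold lower number (1.53 log units; beyond the scatter) from compound 2 to compound 4, 9.2-fold (0.96 log units) apart, beyond the scatter of two such steps. These two pairs do not show what sets the size of the step, and they cannot predict its size on any further core.

From the compounds shown here alone, it remains open how the step would behave with an amine or a carboxylic acid in place of the chlorine of compound 1. Also open, going by these compounds, is whether a longer chain in place of the methyl that compound 1 and compound 4 keep would change the number at all.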